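This account rests on a few compounds, and the source may have more. Where it says the series, first, only, none or still open, it means among the compounds named here.

Working notes on a small series of compounds sharing one core, read in a functional assay on DU-145 cells (Homo sapiens) for inhibition, read by trypan blue exclusion, with a stated time of 96 h; a higher number here means a weaker inhibitor of growth, a lower number a stronger inhibitor of growth.

Compound 1 `Cc1ccc(CS(=O)(=O)/C(=C/c2ccc(Br)cc2)C(=O)c2ccc(Cl)cc2)cc1` gives 25000 nM. Compound 3 `Cc1ccc(CS(=O)(=O)/C(=C/c2sccc2C)C(=O)c2ccc(Cl)cc2)cc1` gives 25000 nM. The two differ only in 4-bromophenyl in place of 3-methylthiophen-2-yl on a double-bonded chain carbon bound to a double-bonded chain carbon, and the step of no change at the digits printed from compound 3 to compound 1 (within the scatter) shows that this exchange leaves the read-out where it was.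

Compound 2 `Cc1ccsc1/C=C(\C(=O)c1ccc(Cl)cc1)S(=O)(=O)Cc1ccc(F)cc1` gives 10000 nM. Compound 2 and compound 3 differ in the core itself by fluoro in place of methyl on an aromatic carbon, and the step of a 2.5-fold higher number from compound 2 to compound 3 (0.40 log units; beyond the scatter) is the only one in the set that moves the number beyond the scatter. Compound 2 therefore holds the lowest number of the three, with both compound 1 and compound 3 standing at the same distance from it.

Compound 4 `O=C(/C(=C\c1ccc(Br)cc1)S(=O)(=O)Cc1ccc(F)cc1)c1ccc(Cl)cc1` has not yet been measured. Among the measured compounds shown here, it relates to compound 2 through (4-bromophenyl in place of 3-methylthiophen-2-yl on a double-bonded chain carbon bound to a double-bonded chain carbon), which is the same change as the one between compound 3 and compound 1; the place at which it is made is described in the same words in both pairs, so the change is taken as the same, made on the core of compound 2 rather than the core of compound 3.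

The expectation for compound 4 rests on compound 3, where the step of no change at the digits printed from compound 3 to compound 1 (within the scatter) was flat, so the step of no change at the digits printed from compound 2 to compound 4 (within the scatter) is estimated to be flat as well. Compound 4 is expected to give 10000 nM in this assay, with a range from 5000 nM to 25000 nM. For the measured compounds named here, only one precedent for this exchange exists in the set, so the range is kept wide.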

Compound 4, concentration for 50% growth inhibition: > 100000 nM
Compound 4 ended at the assay's limit (the forecaster's own chance of this, stated with the estimate: 10%); middle value at least 10-fold (1.00 log units) from the limit.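

In this assay the exchange to 4-bromophenyl does not carry from one core to the other, with an at least 10-fold higher number from compound 2 to compound 4 (1.00 log units; beyond the scatter) set against a flat step on the core of compound 3: the same change on two cores in this assay, no change at the digits printed (within the scatter) from compound 3 to compound 1 and an at least 10-fold higher number (1.00 log units; beyond the scatter) from compound 2 to compound 4, at least 10-fold (1.00 log units) apart, beyond the scatter of two such steps. The exchange of fluoro in place of methyl on an aromatic carbon also reads differently on the two cores. The new step for this exchange is an at least 4.0-fold higher number from compound 1 to compound 4 (0.60 log units; beyond the scatter). The same exchange runs the other way on the other core, where compound 2 has a lower number than compound 3: the same change on two cores in this assay, a 2.5-fold higher number (0.40 log units; beyond the scatter) from compound 2 to compound 3 and an at least 4.0-fold lower number (0.60 log units; beyond the scatter) from compound 4 to compound 1, at least 10-fold (1.00 log units) apart, beyond the scatter of two such steps. Neither exchange therefore behaves as a fixed increment across these four compounds, but two pairs give no general rule, no reason for the difference and no true size for either new step, as compound 4 sits at a limit of the assay and not at a number: the limit of > 100000 nM in this assay, at which 1 of the 4 values shown sits.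

The compounds shown leave open whether the sharp rise on the core of compound 2 belongs to the bromine or to the six-membered aromatic ring, which a plain phenyl or a 4-chlorophenyl group would help to separate. They also leave open how that core would respond to an amine or a carboxylic acid on the ring that enters, or to a longer chain at the sulfonyl group.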